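The compounds below may be only part of what the source reports. "The series", "measured", "known", "first", "only" and "open" are said of these compounds alone.

Of the compounds shown here, three built on a shared core have been tested in a functional assay on CHO cells for antagonist activity at adenosine receptor A2b (Homo sapiens), read by cAMP accumulation, with a stated time of 10 min (on this read-out higher numbers stand for weaker inhibition and lower numbers for stronger inhibition), and none has yet given a number. Compound 1 `N#Cc1cccc(-c2nc(N)c3nc(-c4ccccc4)sc3n2)c1` carries a cyano group; in this assay compound 1 reaches only the limit of > 30000 nM. Compound 2 `Nc1nc(-c2cccc(CO)c2)nc2sc(-c3ccco3)nc12` carries a hydroxymethyl group; compound 2 likewise stands at the limit of > 30000 nM. Compound 3 `COc1cccc(-c2nc(N)c3nc(-c4ccco4)sc3n2)c1` carries a methoxy in place of the hydroxymethyl of compound 2; compound 3 is again reported only as the limit of > 30000 nM. The step that the two limits leave unreadable from compound 2 to compound 3 therefore cannot be read in size or direction. All that is known is the limit of > 30000 nM in this assay, at which 3 of the 3 values shown sit.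

Compound 4 `N#Cc1cccc(-c2nc(N)c3nc(-c4ccco4)sc3n2)c1` is not yet measured. It differs from compound 3 by cyano in place of methoxy on an aromatic carbon; the change sits on an aromatic carbon of a six-membered aromatic ring of carbon only, meta to a large group. Within the data shown here, no measured step bears on this exact change. Compound 1, which also carries a cyano group, shows only a limit, and compound 3 shows only a limit. The expected step is therefore a step that the limit leaves unreadable from compound 3 to compound 4, nothing beyond the scatter. Compound 4 is estimated at 45000 nM, with a range from 15000 nM to 150000 nM, most likely again reported only as a limit.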

Compound 4, half-maximal inhibitory concentration: > 30000 nM
Compound 4 was reported as a limit; the forecaster's own chance of this, stated with the estimate: 85%; the middle value is on the limit's open side.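

In this assay compound 4 gives only a limit, > 30000 nM. Its steps from compound 1, compound 2 and compound 3 therefore cannot be read in size or direction. The compounds shown leave open how strongly any of them inhibits and whether any change on the shared core matters, since all rest at one mark: the limit of > 30000 nM in this assay, at which 4 of the 4 values shown sit.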